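A few compounds are considered here, and "the series" means these few. Any claim that something is new, unique, unknown or untested is made for them only; others in the source may bear on it.

Measured compounds, with values in a functional assay on 1321-N1 cells for agonist activity at P2Y purinoceptor 2 (Homo sapiens), read by scintillation counting and inositol phosphate accumulation; a higher number here means that more compound is needed for the effect, a lower number that less compound is needed:
compound 1 `O=c1[nH]/c(=N\OCCCCc2ccccc2)ccn1[C@@H]1O[C@H](COP(=O)(O)OP(=O)(O)OP(=O)(O)O)[C@@H](O)[C@H]1O`: compound 1 gives 214 nM
compound 2 `O=c1[nH]/c(=N\OCCCc2ccc(I)cc2)ccn1[C@@H]1O[C@H](COP(=O)(O)OP(=O)(O)OP(=O)(O)O)[C@@H](O)[C@H]1O`: compound 2 gives 187 nM

Compound 2 holds the lowest of the two numbers in this assay, but its nearest neighbour is compound 1, and the step of a 1.1-fold lower number from compound 1 to compound 2 (0.06 log units; within the scatter) lies within the scatter, so no order between the two can be read.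

Compound 3 `O=c1[nH]/c(=N\OCCCc2cccc([N+](=O)[O-])c2)ccn1[C@@H]1O[C@H](COP(=O)(O)OP(=O)(O)OP(=O)(O)O)[C@@H](O)[C@H]1O` differs from compound 2 by 3-nitrophenyl in place of 4-iodophenyl on a saturated chain carbon, three bonds along the chain from an oxygen. Among the compounds with values here, the only measured step that touches the same region of the molecule is a 1.1-fold lower number from compound 1 to compound 2 (0.06 log units; within the scatter), where a change of the aryl group at the end of the chain left the number essentially unchanged. Nothing measured speaks to a nitro group in this position. The expectation for compound 3 in this assay is therefore a step of a 1.3-fold higher number from compound 2 to compound 3 (0.13 log units; within the scatter), that is, no change beyond the scatter, with a wide range to reflect the missing precedent. Compound 3 is estimated at 250 nM, between 90 nM and 700 nM.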

Compound 3, half-maximal effective concentration: 457 nM
The estimate for compound 3 lay 1.8-fold (0.26 log units) below the measured number; the measured number falls inside the stated range.
By their numbers in this assay, from the lowest: compounds 2 and 1 (each within the scatter of the next); then compound 3.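

In this assay, the aryl end of the chain now shows a readable response to substitution: 3-nitrophenyl in place of 4-iodophenyl gives a 2.4-fold higher number from compound 2 to compound 3 (0.39 log units; beyond the scatter). The same group in place of benzyl gives a 2.1-fold higher number from compound 1 to compound 3 (0.33 log units; beyond the scatter), so compound 3 stands apart from both compound 1 and compound 2, which cannot be separated from each other. No measurement at hand accounts for these steps.

The compounds shown leave open whether the higher number follows the nitro group itself or the departure of the groups it replaces, since each step exchanges a whole aryl end. Going by these compounds, how an amine or a carboxylic acid on the aromatic ring, or a longer chain carrying 3-nitrophenyl, would read in this assay also remains open.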